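Second Methoxy on an Aryl Ring Already at the Limit

The compounds below may be only part of what the source reports. "The series", "measured", "known", "first", "only" and "open" are said of these compounds alone.

Measured so far in a functional assay on HepG2 cells (Homo sapiens) for cytotoxicity, read by MTT assay, with a stated time of 72 h; a higher number here means a weaker inhibitor, a lower number a stronger inhibitor:
compound 1 `NS(=O)(=O)c1ccc(-n2ncc3c(=O)[nH]c(-c4ccc(F)cc4)nc32)cc1`: 2660 nM
compound 2 `NS(=O)(=O)c1ccc(-n2ncc3c(=O)[nH]c(-c4ccc(Cl)cc4)nc32)cc1`: 23900 nM
compound 3 `COc1ccc(-c2nc3c(cnn3-c3ccc(S(N)(=O)=O)cc3)c(=O)[nH]2)cc1`: > 100000 nM

Three compounds share one core and differ only in the group on the pendant aryl ring. Compound 1 gives the lowest number of the three in this assay. Replacing its fluoro by chloro gives a 9.0-fold higher number from compound 1 to compound 2 (0.95 log units; beyond the scatter). Replacing the fluoro by methoxy gives an at least 37-fold higher number from compound 1 to compound 3 (1.57 log units; beyond the scatter), and the chloro-to-methoxy comparison gives an at least 4.1-fold higher number from compound 2 to compound 3 (0.62 log units; beyond the scatter). The result for compound 3 is a limit of the assay and not a number: compound 3 sits at the limit of > 100000 nM in this assay, at which 1 of the 3 values shown sits.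

Compound 4 `COc1ccc(-c2nc3c(cnn3-c3ccc(S(N)(=O)=O)cc3)c(=O)[nH]2)cc1OC` differs from compound 3 by methoxy in place of hydrogen on an aromatic carbon. Among the compounds with values here, no measured step adds a second methoxy, so the three steps bear on it only loosely; all three, however, move the number upward as the substituent is changed, and the starting point for compound 4 is already at the limit. Compound 4 is therefore expected to remain at or beyond that limit, with an expected step that the limit leaves unreadable from compound 3 to compound 4. The estimate for compound 4 in this assay is 200000 nM, within a range from 60000 nM to 700000 nM.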

Compound 4, half-maximal inhibitory concentration: > 100000 nM
Compound 4: only a limit was reported; the forecaster's own chance of this, stated with the estimate: 85%; the middle value is on the limit's open side.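

In this assay the result for compound 4 is a limit and not a number, as is the result for compound 3, and the step between them cannot be read: the limit of > 100000 nM in this assay, at which 2 of the 4 values shown sit.

What compound 4 does show is that the 3,4-dimethoxyphenyl group, like the 4-methoxyphenyl group of compound 3, stays clear of both halogen-bearing compounds, with an at least 4.1-fold higher number from compound 2 to compound 4 (0.62 log units; beyond the scatter) and an at least 37-fold higher number from compound 1 to compound 4 (1.57 log units; beyond the scatter). A methoxy placed ortho to a methoxy group therefore does not bring the number back into the range that this assay reads, so the loss seen with the first methoxy is not undone by the second.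

The compounds shown leave open whether the second methoxy changes the true number at all, since both results lie past the same limit. They also leave open what a hydroxyl or an amine at this place would do on the 4-fluorophenyl ring of compound 1, which at 2660 nM starts from a readable value.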